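The source may report more compounds than this note shows. Statements on the series, on what has been measured and on what is new or still open speak of the compounds shown alone.

Working notes on the series.

Two compounds of this set have numbers in a functional assay on ZR-75-1 cells (Homo sapiens) for cytotoxicity, read by sulforhodamine B assay, with a stated time of 72 h; on this read-out higher numbers stand for an effect only at larger amounts of compound and lower numbers for an effect already at smaller amounts. Compound 1 `CCCC[C@H](O)/C=C\[C@@H]1OC(=O)C=C[C@@H]1OC(C)=O` gives in this assay a value of 1.6 ug/mL, the lower of the two numbers. Compound 2 `CCCC[C@H](OC(C)=O)[C@@H](OC(C)=O)[C@H](OC(C)=O)[C@H]1CC=CC(=O)O1` gives in this assay a value of 8.7 ug/mL, a higher number than compound 1, and the gap between the two lies beyond the usual scatter. Compound 2 differs from compound 1 in several places at once, so no single change can be read from this pair; the two values are all that the pair shows.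

Compound 3 `CCCC[C@@H](/C=C\[C@@H]1OC(=O)C=C[C@@H]1OC(C)=O)OC(C)=O` is the next compound and has not yet been measured in this assay. It differs from compound 1 in one place: acetyl in place of hydrogen on an oxygen on a saturated carbon. The shared core is kept, as is the chain.

Going by the values given here, no measured pair in this set isolates this change. The expectation for compound 3 in this assay is therefore a small step, a 1.6-fold higher number from compound 1 to compound 3 (0.19 log units; within the scatter), not clearly beyond the scatter, leaning toward a higher number. Compound 3 is estimated at 2.5 ug/mL, with a range from 0.9 ug/mL to 7 ug/mL.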

Compound 3, concentration for half-maximal effect: 3.6 ug/mL
The estimate for compound 3 lay 1.4-fold (0.16 log units) below the measured number; the range from low to high includes it.
By their numbers in this assay, from the lowest: compound 1; then compound 3; then compound 2.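

In this assay, going by these compounds alone, this is the first pair that isolates a single change: acetyl in place of hydrogen on an oxygen on a saturated carbon, hydroxy to acetoxy, gives a 2.3-fold higher number from compound 1 to compound 3 (0.35 log units; beyond the scatter). The step is modest, and it shows that this position responds to the change, while capping the hydroxy does not abolish the read-out, as compound 3 still gives 3.6 ug/mL. No measurement shown here accounts for the direction or size of this step, and the reason for it remains unexplained.

The compounds shown leave open how the read-out responds to other groups at this position, such as a methyl ether, a longer butyryl ester, or an amine in place of the hydroxy, so a single acetyl step cannot say whether the hydroxy itself matters or whether any capping group would give the same result. They also leave open whether the same step would appear with the acetoxy on the shared core replaced by hydroxy, or with a longer chain in place of the present one.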